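The source may hold more compounds than are shown below. What is called first, only, known or untested is meant among the compounds shown, and "the series" means these compounds.

Of the compounds shown here, two have been measured in an assay on a protein complex for inhibition of CDK8/Cyclin C (Homo sapiens), with a stated time of 1 h; a lower number here means a stronger inhibitor, a higher number a weaker inhibitor. Compound 1 `CN1CCN(C(=O)/C=C/c2ccncc2-c2ccc3ccccc3c2)CC1` gives 43.6 nM in this assay. Compound 2 `O=C(/C=C/c1ccncc1-c1ccc2ncccc2c1)N1CCOCC1` differs from compound 1 in more than one place, both in its core and in the amide. In this assay compound 2 gives 1590 nM. Of these two numbers the value of compound 1 is the lower one, and the gap to compound 2 lies beyond the scatter, so compound 1 is the stronger inhibitor of the pair. The two measured compounds differ in several places at once. No single structural change can be isolated from them.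

Compound 3 `O=C(O)CCNC(=O)/C=C/c1ccncc1-c1ccc2ccccc2c1` keeps the core of compound 1 and alters only the amide portion: (2-carboxyethyl)amino in place of 4-methylpiperazin-1-yl on a carbonyl carbon. For the measured compounds named here, no measured pair shows what this exchange does, so the expectation rests on the general pattern that amide variations of this kind rarely swing the number by more than a modest amount. The step from compound 1 to compound 3 is expected to be small and directed towards a somewhat higher number, a 2.5-fold higher number from compound 1 to compound 3 (0.40 log units; beyond the scatter). On that basis compound 3 is estimated to give 110 nM in this assay, with a range from 30 nM to 400 nM.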

Compound 3, half-maximal inhibitory concentration: 870 nM
Compound 3: the middle estimate sits 7.9-fold (0.90 log units) below what was measured; measured number outside the range, above it.
By their numbers in this assay, from the lowest: compound 1; then compounds 3 and 2 (each within the scatter of the next).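

With the core of compound 1 held fixed, exchanging the group on the carbonyl carbon changes the result in this assay: (2-carboxyethyl)amino in place of 4-methylpiperazin-1-yl gives a 20-fold higher number from compound 1 to compound 3 (1.30 log units; beyond the scatter). For the compounds shown here, this is the only comparison so far in which the structures differ in one place, so the amide portion can now be seen to shift the number on its own, something compound 1 and compound 2 could not show, since they differ in both core and amide. The exchange replaces a ring with an open chain and adds hydrogen-bond donors, but no measurement shown here connects the step to either of those differences or to any other cause.

Going by these compounds, a single step cannot separate the loss of the 4-methylpiperazin-1-yl ring from the arrival of the carboxylic acid, so it remains open where a piperidin-1-yl ring, or the same chain ending in a methyl ester or a primary amine, would fall relative to compound 1 and compound 3. On these data alone, it also remains open whether an exchange of this kind would have a similar effect on a different core.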